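Changing the Aryl Group on the Carbonyl Carbon

This account rests on a few compounds, and the source may have more. Where it says the series, first, only, none or still open, it means among the compounds named here.

Of the compounds shown here, three sharing one core have been tested in a functional assay on A549 cells (Homo sapiens) for antiproliferative activity, read by XTT assay, with a stated time of 72 h; a higher number here means a weaker inhibitor, a lower number a stronger inhibitor. Compound 1 `COc1ccc(-c2cc3ccccc3nc2/C=C/C(=O)c2ccccc2)cc1` gives 7410 nM, the second highest of the three numbers. Compound 2 `COc1ccc(-c2cc3ccccc3nc2/C=C/C(=O)c2ccc(OC)cc2OC)cc1` gives 7990 nM, and the step of a 1.1-fold higher number from compound 1 to compound 2 (0.03 log units; within the scatter) shows that putting 2,4-dimethoxyphenyl in place of phenyl on the carbonyl carbon changed nothing that can be trusted. Compound 3 `COc1ccc(-c2cc3ccccc3nc2/C=C/C(=O)c2cccs2)cc1` gives 920 nM, and the step of an 8.1-fold lower number from compound 1 to compound 3 (0.91 log units; beyond the scatter) shows a real gain; the step of an 8.7-fold lower number from compound 2 to compound 3 (0.94 log units; beyond the scatter) points the same way.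

Compound 4 `COc1ccc(-c2cc3ccccc3nc2/C=C/C(=O)c2cnc(N)nc2C)cc1` is not yet measured. Compared with compound 1, the change is 2-amino-4-methylpyrimidin-5-yl in place of phenyl on a carbonyl carbon. The two measured steps at this position bear on it: one aromatic group left the number unchanged, another lowered it. The entering group resembles neither closely, so the direction is uncertain and only a modest effect is expected. The expected step is therefore a 1.6-fold lower number from compound 1 to compound 4 (0.22 log units; within the scatter). In this assay compound 4 is estimated at 4500 nM, most likely between 900 nM and 22000 nM.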

Compound 4, half-maximal inhibitory concentration: > 10000 nM
Compound 4 ended at the assay's limit (the forecaster's own chance of this, stated with the estimate: 10%); middle value at least 2.2-fold (0.34 log units) from the limit.
By their numbers in this assay, from the lowest: compound 3; then compounds 1 and 2 (each within the scatter of the next). At a limit, above all of these: compound 4.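

In this assay compound 4 stands at a limit rather than at a number: the limit of > 10000 nM in this assay, at which 1 of the 4 values shown sits.

The step of an at least 10-fold higher number from compound 3 to compound 4 (1.03 log units; beyond the scatter) is beyond the scatter, so at this position a ring containing hetero atoms does not by itself bring the gain seen with thiophen-2-yl. The other two steps, an at least 1.3-fold higher number from compound 1 to compound 4 (0.13 log units; that floor lies within the scatter) and an at least 1.2-fold higher number from compound 2 to compound 4 (0.09 log units; that floor lies within the scatter), have floors within the scatter, so 2-amino-4-methylpyrimidin-5-yl may match phenyl and 2,4-dimethoxyphenyl or fall well short of them.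

The compounds shown do not separate the contributions of the amine and the methyl on the pyrimidine ring, as a plain pyrimidin-5-yl group could. They also leave open whether the gain belongs to thiophen-2-yl alone or extends to a related ring such as furan-2-yl.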